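The source may report more compounds than this note shows. Statements on the series, on what has been measured and on what is new or still open speak of the compounds shown alone.

For the measured compounds named here, compound 3 `CC(C)CC1C(=O)N(C)c2cnc(Nc3ccc(S(N)(=O)=O)cc3)nc2N1C` gives 77 nM in an assay on Sf9 cells for inhibition of serine/threonine-protein kinase 4 (Homo sapiens), read by luminescence and ADP-Glo, with a stated time of 1 h, in the presence of a further agent that is not named here (a higher number here means a weaker inhibitor, a lower number a stronger inhibitor), the lowest of the three numbers measured so far. Compound 1 `CC1C(=O)N(C)c2cnc(Nc3ccc(S(N)(=O)=O)cc3)nc2N1C` gives 313 nM and compound 2 `CCC1C(=O)N(C)c2cnc(Nc3ccc(S(N)(=O)=O)cc3)nc2N1C` gives 479 nM in this assay. Between the first two there was a 1.5-fold higher number from compound 1 to compound 2 (0.18 log units; within the scatter), whereas there was a 4.1-fold lower number from compound 1 to compound 3 (0.61 log units; beyond the scatter) and a 6.2-fold lower number from compound 2 to compound 3 (0.79 log units; beyond the scatter); growing the group on the saturated chain carbon from hydrogen or methyl to isopropyl therefore made a stronger inhibitor. Compound 4 `COc1cccc(C2C(=O)N(C)c3cnc(Nc4ccc(S(N)(=O)=O)cc4)nc3N2C)c1` carries a different kind of change: 3-methoxyphenyl in place of isobutyl on a saturated ring carbon. Going by the values given here, none of the measured steps swaps a chain for an aromatic ring, so they bear only loosely on this one; they show that a larger group at this position was tolerated and helped, but the 3-methoxyphenyl is a different shape from any chain tried. The expected step in this assay is therefore small, in either direction, and may well lie within the scatter: the estimate is a 1.3-fold higher number from compound 3 to compound 4 (0.11 log units; within the scatter). Compound 4 is expected to give about 100 nM in this assay, with a range from 25 nM to 400 nM.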

Compound 4, half-maximal inhibitory concentration: 954 nM
Compound 4: the middle estimate sits 9.5-fold (0.98 log units) below what was measured, outside the stated range (above it).
By their numbers in this assay, from the lowest: compound 3; then compounds 1, 2 and 4 (each within the scatter of the next, the first and the last beyond it).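

In this assay, adding heavy atoms at this saturated ring carbon does not by itself give a stronger inhibitor: replacing isobutyl with 3-methoxyphenyl, which brings a six-membered aromatic ring, gives a 12-fold higher number from compound 3 to compound 4 (1.09 log units; beyond the scatter) and loses the gain seen with isobutyl. Compared with the smaller chains, the change gives a 3.0-fold higher number from compound 1 to compound 4 (0.48 log units; beyond the scatter) from methyl and a 2.0-fold higher number from compound 2 to compound 4 (0.30 log units; within the scatter) from ethyl, so the aromatic group is a weaker choice than methyl and cannot be told apart from ethyl. Nothing measured here gives a reason for this loss.

The compounds shown leave open whether the aromatic ring or its methoxy group matters more, a question that a plain phenyl group would help to answer. They also leave open whether a longer chain or a cyclohexyl group at this carbon would match or improve on isobutyl.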